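A few compounds are considered here, and "the series" means these few. Any claim that something is new, unique, unknown or untested is made for them only; others in the source may bear on it.

Values so far in a physicochemical assay for solubility, in phosphate buffer, measured as kinetic solubility, with a stated time of 1 h, at pH 7.4; a lower number here means a less soluble compound, a higher number a more soluble compound
compound 1 `CS(=O)(=O)Cc1cc(C2=CCOCC2)nc(-c2cccc(O)c2)n1` gives 27 ug/mL
compound 2 `CCNC(=O)Nc1ccc(-c2nccc([C@]34CCOC[C@H]3C4)n2)cc1` gives 125 ug/mL
compound 3 `CCNC(=O)Nc1ccc(-c2nccc([C@@]34CCOC[C@@H]3C4)n2)cc1` gives 127 ug/mL

Compound 3, at 127 ug/mL, stands level with compound 2 at 125 ug/mL, the two lying within the scatter of each other. Compound 1 shows the lower number of the set at 27 ug/mL.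

Next in the series is compound 4 `CCNC(=O)Nc1ccc(-c2nccc(C34CCOCC3C4)n2)cc1`. The change is the two compounds have the same atoms and bonds; at least one stereo element is drawn with a configuration in one of them and without one in the other: 2 of 2 stereo elements differ; a stereocentre at a saturated ring carbon is drawn S in compound 3 and without a configuration in compound 4; a stereocentre at a saturated ring carbon is drawn R in compound 3 and without a configuration in compound 4. Nothing leaves and nothing enters; the stereocentres at the two saturated ring carbons are simply drawn without a configuration.

Within the data shown here, one measured step bears on this change: a 1.0-fold higher number from compound 2 to compound 3 (0.01 log units; within the scatter), between mirror images and within the scatter. Its relevance comes from the fact that compounds 2 and 3 differ only in the configuration as drawn. With the two drawn forms level in this assay, no step beyond the scatter is expected, and neither direction is favoured. The estimated step is a 1.0-fold lower number from compound 3 to compound 4 (0.01 log units; within the scatter). Compound 4 is expected at 125 ug/mL, with an estimated range of 75 ug/mL to 190 ug/mL.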

Compound 4, solubility: 111 ug/mL
The estimate for compound 4 lay 1.1-fold (0.05 log units) above the measured number; the measured number falls inside the stated range.
By their numbers in this assay, from the lowest: compound 1; then compounds 4, 2 and 3 (each within the scatter of the next).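

Drawing the two saturated ring carbons without a configuration leaves the number in this assay level with both drawn forms (a 1.1-fold lower number from compound 3 to compound 4 (0.06 log units; within the scatter)) and (a 1.1-fold lower number from compound 2 to compound 4 (0.05 log units; within the scatter)). The earlier compounds shown here offered only the comparison between mirror images, whereas the series now shows that all three drawings of this structure read alike, so no drawn configuration at these two carbons stands apart in this assay. The comparison with compound 2 rests on a difference in drawing alone, with no atom or bond changed: the fact that one of compounds 2 and 4 is drawn with a defined configuration and the other without, at the place where they differ

The compounds shown do not tell how far this level reading would hold once the atoms at these carbons change, for instance with an amine or a carboxylic acid attached there. They also leave open whether configuration would still read level in this assay with such a group in place.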